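This account rests on a few compounds, and the source may have more. Where it says the series, first, only, none or still open, it means among the compounds named here.

Compound 1 `Cc1ccc([C@@H](C)Oc2cc3onc(CCC(=O)O)c3cc2Cl)nc1`: 0.31 L/kg
Compound 2 `O=C(O)CCn1c(=O)oc2cc(Cl)c(Cl)cc21`: 0.28 L/kg

Among the measured compounds shown here, in an ADME assay on the whole organism (strain Han-Wistar) for pharmacokinetics, with Rattus norvegicus as the target, read by LC-MS, at a dose of 1 mg/kg by the intravenous route (a higher number here means that more of the compound sits outside the plasma, a lower number that more of the compound stays in the plasma), compound 1 gives 0.31 L/kg and compound 2 gives 0.28 L/kg, two numbers within the scatter of each other, so compound 1 cannot be told apart from the only other measured compound.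

Compound 3 `Cc1ccc([C@@H](C)Oc2cc3onc(CCC(=O)O)c3cc2Cl)nn1` keeps the core of compound 1 and carries one change: 6-methylpyridazin-3-yl in place of 5-methylpyridin-2-yl on a saturated chain carbon bound to an oxygen on an aromatic ring and a saturated chain carbon. Here 6-methylpyridazin-3-yl stands in place of 5-methylpyridin-2-yl on a saturated chain carbon bound to an oxygen on an aromatic ring and a saturated chain carbon. For the measured compounds named here, no measured pair differs in one place only, so the data offer no direct precedent for this change. The expectation in this assay is no shift beyond the scatter, with a slight lean to a lower number. The estimated step of a 1.2-fold lower number from compound 1 to compound 3 (0.08 log units; within the scatter) is accordingly small. Compound 3 is estimated at 0.26 L/kg, with an expected range from 0.15 L/kg to 0.45 L/kg.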

Compound 3, volume of distribution at steady state: 1.1 L/kg
Compound 3: middle estimate off by 4.2-fold (0.63 log units), on the low side; the whole stated range lies below it.
By their numbers in this assay, from the lowest: compounds 2 and 1 (each within the scatter of the next); then compound 3.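

In this assay, 6-methylpyridazin-3-yl in place of 5-methylpyridin-2-yl gives a 3.5-fold higher number from compound 1 to compound 3 (0.55 log units; beyond the scatter), which shows that the group on this saturated chain carbon can move the number with the rest of compound 1 held fixed. The earlier pair could not show this, as compound 1 and compound 2 differ in more than one place, whereas here the group entering keeps the same heavy-atom count and has one more ring nitrogen. Nothing given here bears on why the number moves.

The compounds shown leave open whether any ring with a second nitrogen, such as a methylpyrimidinyl group, would give a similar step, or whether this depends on the pyridazine itself. They also leave open whether the step would hold with an ethyl group or a chlorine in place of the methyl, or with a tetrazole in place of the carboxylic acid.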